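This account rests on a few compounds, and the source may have more. Where it says the series, first, only, none or still open, it means among the compounds named here.

Measured compounds:
compound 1, `COCc1cc(-c2ccccc2)c2ccc(OCc3cccc(C4(O)CCOCC4)c3)cc2c1`, 160 nM
compound 2, `N#Cc1cc(-c2ccoc2)c2ccc(OCc3cccc(C4(O)CCOCC4)c3)cc2c1`, 30 nM
compound 3, `OC1(c2cccc(COc3ccc4c(-c5ccoc5)cc(C5=NCCO5)cc4c3)c2)CCOCC1`, 70 nM

All three share one core and differ in the group carried on one aromatic carbon of that core. In an assay on isolated protein with Polyunsaturated fatty acid 5-lipoxygenase (Homo sapiens) as the target (on this read-out lower numbers stand for stronger inhibition and higher numbers for weaker inhibition), compound 2 gives 30 nM, the lowest of the three numbers. Compound 3, with 70 nM, stands second highest: the step of a 2.3-fold higher number from compound 2 to compound 3 (0.37 log units; beyond the scatter) lies beyond the scatter, and compound 1, with 160 nM, lies higher still, also beyond the scatter.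

Compound 4, `CC1(C)COC(c2cc(-c3ccoc3)c3ccc(OCc4cccc(C5(O)CCOCC5)c4)cc3c2)=N1`, has not yet been measured. It differs from compound 3 by a group of 7 heavy atoms (5 carbon, 1 nitrogen, 1 oxygen; one five-membered non-aromatic ring with 2 hetero atoms) in place of a group of 5 heavy atoms (3 carbon, 1 nitrogen, 1 oxygen; one five-membered non-aromatic ring with 2 hetero atoms), on an aromatic carbon. For the measured compounds named here, no measured step touches this ring once it is in place; the one measured step, a 2.3-fold higher number from compound 2 to compound 3 (0.37 log units; beyond the scatter), put the ring in place of a nitrile and was modest. The ring that enters in compound 4 is of the same kind as the one that leaves, only with more carbon as the count shows, a smaller change than exchanging a nitrile for a ring, so in this assay no step beyond the scatter is expected: no change at the digits printed from compound 3 to compound 4 (within the scatter). Compound 4 is therefore estimated at 70 nM, with a range from 35 nM to 140 nM.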

Compound 4, half-maximal inhibitory concentration: 190 nM
Compound 4: the middle estimate sits 2.7-fold (0.43 log units) below what was measured; the measured number lies above the stated range.
By their numbers in this assay, from the lowest: compound 2; then compound 3; then compounds 1 and 4 (each within the scatter of the next).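

In this assay this aromatic carbon proves sensitive to a change that looks small on paper. The step of a 2.7-fold higher number from compound 3 to compound 4 (0.43 log units; beyond the scatter) comes with the five-membered ring, its double bond and its hydrogen-bond counts all unchanged, so added carbon on the ring alone is enough to move the number beyond the scatter. Against the nitrile, the step of a 6.3-fold higher number from compound 2 to compound 4 (0.80 log units; beyond the scatter) is wider than the step of a 2.3-fold higher number from compound 2 to compound 3 (0.37 log units; beyond the scatter), so among these three compounds, which differ only at this carbon, the nitrile gives the lowest number and the larger ring group the highest, yet nothing given here bears on why the added carbon has this effect.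

For the compounds shown here, with only three groups compared at this position on the furan-3-yl series, it stays open whether a carboxylic acid, an amine or a methyl ester on this carbon would fall below the number of the nitrile. From the compounds shown here alone, it also stays open whether the rise follows the amount of carbon added or where it sits, and a ring carrying a single methyl group would speak to that question.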